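Nitro to fluoro swap tested on a second core

The source may hold more compounds than are shown below. What is called first, only, known or untested is meant among the compounds shown, and "the series" means these compounds.

Measured compounds:
compound 1, `COc1ccc(-c2cc(=O)c3c(OC)cc(OC)cc3n2S(=O)(=O)c2ccc([N+](=O)[O-])cc2)cc1`, 17100 nM
compound 2, `COc1ccc(-c2cc(=O)c3c(OC)cc(OC)cc3n2S(=O)(=O)c2ccc(F)cc2)cc1`, > 65500 nM
compound 3, `COc1cc(OC)c2c(=O)cc(C(=O)Nc3ccc(Oc4ccc([N+](=O)[O-])cc4)cc3)[nH]c2c1`, 4300 nM

All three were tested in a functional assay on SUP-B15 cells (Homo sapiens) for antiproliferative activity, with a stated time of 72 h; on this read-out lower numbers stand for an effect already at smaller amounts and higher numbers for an effect only at larger amounts of compound. Compound 1 gives 17100 nM. Compound 2 reaches only a limit of this assay, > 65500 nM. That reading is the limit of > 65500 nM in this assay, at which 1 of the 3 values shown sits. The change between them is fluoro in place of nitro on an aromatic carbon, and it made the step of an at least 3.8-fold higher number from compound 1 to compound 2 (0.58 log units; beyond the scatter). Compound 3 gives 4300 nM, the lowest number among the measured compounds; how its core differs from the core of compound 1 is not broken down here.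

Compound 4, `COc1cc(OC)c2c(=O)cc(C(=O)Nc3ccc(Oc4ccc(F)cc4)cc3)[nH]c2c1`, has not yet been measured. It differs from compound 3 by fluoro in place of nitro on an aromatic carbon, the same change already seen from compound 1 to compound 2, at a place described in the same words. For compound 4 the expected step is a 4.2-fold higher number from compound 3 to compound 4 (0.62 log units; beyond the scatter), an expectation resting on the earlier at least 3.8-fold higher number from compound 1 to compound 2 (0.58 log units; beyond the scatter), with the chance that a limit rather than a number is reported. Compound 4 is therefore estimated at 18000 nM, most likely between 5000 nM and 65000 nM.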

Compound 4, half-maximal effective concentration: > 50000 nM
Compound 4: no number, only a limit; the forecaster's own chance of this, stated with the estimate: 25%; middle value at least 2.7-fold (0.44 log units) from the limit.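

In this assay compound 4 gives > 50000 nM, which is a limit of the assay and not a number. Fluoro in place of nitro gave an at least 11-fold higher number from compound 3 to compound 4 (1.06 log units; beyond the scatter), so on both cores shown, the swap moved the read-out in the same direction, towards needing more compound for an effect. This does not show that the size of the step carries over from one core to the other, since both fluoro compounds end in limits rather than numbers: the same change on two cores in this assay, an at least 3.8-fold higher number (0.58 log units; beyond the scatter) from compound 1 to compound 2 and an at least 11-fold higher number (1.06 log units; beyond the scatter) from compound 3 to compound 4; the limit leaves it open whether they differ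

The compounds shown leave open whether the nitro group itself is what matters or whether other groups at the same place, such as a nitrile, an amine or a carboxylic acid, would give similar numbers on these cores. Among the compounds shown here, with only two pairs, they also leave open whether the same swap would move the read-out in the same direction on any further core.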